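Trifluoromethyl for methyl on the saturated ring carbon

The compounds below may be only part of what the source reports. "The series", "measured", "known", "first", "only" and "open" are said of these compounds alone.

Of the compounds shown here, two have been measured in a functional assay on the whole organism (aorta) with Rattus norvegicus as the target; on this read-out lower numbers stand for smaller maximal responses and higher numbers for larger maximal responses. Compound 1 `CNC(=O)C1=CC(C)(C(F)(F)F)Oc2ccc([N+](=O)[O-])cc21` gives 61.7%. Compound 2 `CC1(C)C=C(C(=O)NCCC#N)c2cc([N+](=O)[O-])ccc2O1` gives 73.1%, the highest of the two numbers, and the gap to compound 1 lies beyond the scatter. Compound 3 `CC1(C(F)(F)F)C=C(C(=O)NCCC#N)c2cc([N+](=O)[O-])ccc2O1` has not yet been measured; it differs from compound 2 by trifluoromethyl in place of methyl on a saturated ring carbon. Within the data shown here, no measured pair shows this change alone. Compound 1, which also carries the trifluoromethyl, gives 61.7%, so for this assay compound 3 is expected to land somewhat lower, a step of a number 7.1 percentage points lower from compound 2 to compound 3 (within the scatter) that stays within the scatter. Compound 3 is estimated at 66%, within 52% to 80%.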

Compound 3, intrinsic activity: the largest response reached, in percent of the reference agonist's: 70.6%
Estimate against measurement, compound 3: 4.6 percentage points below; the measured number falls inside the stated range.
By their numbers in this assay, from the lowest: compounds 1, 3 and 2 (each within the scatter of the next, the first and the last beyond it).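

In this assay, trifluoromethyl in place of methyl on the saturated ring carbon next to the ring oxygen now has a direct pair: a number 2.5 percentage points lower from compound 2 to compound 3 (within the scatter), so this exchange stays inside the scatter here. With trifluoromethyl held, cyanomethyl in place of hydrogen on the saturated chain carbon bound to the amide-type nitrogen gives a number 8.9 percentage points higher from compound 1 to compound 3 (within the scatter), also inside the scatter. No supporting data bear on either step. Open, as far as these compounds go, is whether ethyl on this ring carbon, or a carboxylic acid in place of the nitrile, would also stay inside the scatter.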